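Swapping fluoro for chloro in a bromoacyl urea series

The compounds below may be only part of what the source reports. "The series", "measured", "known", "first", "only" and "open" are said of these compounds alone.

Measured compounds:
compound 1, `CC(Br)C(=O)Nc1ccc(F)c(C(=O)NC(N)=O)c1`: 520 nM
compound 2, `CC(Br)C(=O)Nc1ccc(Cl)c(C(=O)NC(N)=O)c1`: 2550 nM
compound 3, `NC(=O)NC(=O)c1ccc(F)c(NC(=O)CBr)c1`: 2290 nM

All three were tested in a functional assay on CCRF-CEM cells (Homo sapiens) for antiproliferative activity, read by trypan blue exclusion, with a stated time of 72 h; a higher number here means a weaker inhibitor, a lower number a stronger inhibitor. Compound 1 and compound 2 share one core and differ only in one place: chloro in place of fluoro on an aromatic carbon. That swap gave a 4.9-fold higher number from compound 1 to compound 2 (0.69 log units; beyond the scatter), so the chloro compound was the weaker of the pair.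

Compound 3 carries a different arrangement of the same kinds of groups; the difference between its core and the core of compound 1 is not broken down here. In this assay compound 3 gives 2290 nM, which sits close to compound 2 and clearly above compound 1.

Compound 4, `NC(=O)NC(=O)c1ccc(Cl)c(NC(=O)CBr)c1`, has not yet been measured. It differs from compound 3 by chloro in place of fluoro on an aromatic carbon. Going by the values given here, this is the same kind of change as the one from compound 1 to compound 2, but not the same: in the first pair the swapped atom sits ortho to a carbamoylcarbamoyl group and para to a ((1-bromoethyl)carbonyl)amino group, whereas in compound 4 it sits ortho to a ((bromomethyl)carbonyl)amino group and para to a carbamoylcarbamoyl group.

For compound 4 the step is expected to be a 3.0-fold higher number from compound 3 to compound 4 (0.48 log units; beyond the scatter), somewhat smaller than the earlier one since the surroundings differ. This expectation rests on the measured step of a 4.9-fold higher number from compound 1 to compound 2 (0.69 log units; beyond the scatter). Compound 4 is therefore estimated at 6900 nM, with a likely range from 2500 nM to 20000 nM.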

Compound 4, half-maximal inhibitory concentration: 2910 nM
The estimate for compound 4 lay 2.4-fold (0.37 log units) above the measured number; low and high end bracket the measured number.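

In this assay, putting chloro in place of fluoro on the core of compound 3 gave a 1.3-fold higher number from compound 3 to compound 4 (0.10 log units; within the scatter), so this pair cannot be told apart, whereas the same swap on the core of compound 1 clearly weakened the compound. Going by these compounds alone, the change therefore did not carry over at the same size from one core to the other: the same change on two cores in this assay, a 4.9-fold higher number (0.69 log units; beyond the scatter) from compound 1 to compound 2 and a 1.3-fold higher number (0.10 log units; within the scatter) from compound 3 to compound 4, 3.9-fold (0.59 log units) apart, beyond the scatter of two such steps This shows that a step measured on one core is not a safe guide to the other here, but with only two pairs it does not show which difference between the cores matters, whether the swapped atom's place, ortho to a ((bromomethyl)carbonyl)amino group and para to a carbamoylcarbamoyl group, or some other feature, nor how the swap would behave on a third core.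

The compounds shown carry only fluoro or chloro on this aromatic carbon, so how a hydrogen, a methyl group or a nitrile there would compare on either core stays open. Each core also carries its own bromine-bearing chain, which leaves open whether a longer chain, or a chloro in place of the bromo, would change the size of the step.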